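A few compounds are considered here, and "the series" means these few. Any claim that something is new, unique, unknown or untested is made for them only; others in the source may bear on it.

Measured so far:
compound 1 `C/N=C(\S)CCn1nc(-c2ccccc2)ccc1=O` gives 68.2% in a functional assay on the whole organism (stomach) for inhibition, with Rattus norvegicus as the target, at a dose of 100 mg/kg by the intraduodenal route; a lower number here means less inhibition, a higher number more inhibition at the dose given (going by the name of the read-out)
compound 2 `C/N=C(/S)CCCCCn1nc(-c2ccccc2)ccc1=O` gives 92.3% in this assay

Compound 2 stands highest of the two numbers; compound 1 sits a number 24.1 percentage points higher from compound 1 to compound 2 (beyond the scatter) below it. Compound 3 `N=C(S)CCn1nc(-c2ccccc2)ccc1=O` is not yet measured. Going from compound 2 to compound 3, (a group of 3 heavy atoms (1 carbon, 1 nitrogen, 1 sulfur; no ring) in place of a group of 7 heavy atoms (5 carbon, 1 nitrogen, 1 sulfur; no ring), on a saturated chain carbon, two bonds along the chain from an aromatic nitrogen). For the measured compounds named here, the one measured step bears on this directly: the longer group raised inhibition a number 24.1 percentage points higher from compound 1 to compound 2 (beyond the scatter), and compound 3 carries the shorter chain again, so a drop in this assay is expected, roughly reversing that step, a number 27.3 percentage points lower from compound 2 to compound 3 (beyond the scatter). For compound 3 the estimate is 65%, with a range from 40% to 88%.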

Compound 3, a percentage reported as inhibition, in the whole organism at one dose (the size of the read-out at that dose, not a potency): 53.7%
Beside the measured number, compound 3's estimate is 11.3 percentage points above it, and the stated range covers the measured number.
By their numbers in this assay, from the lowest: compound 3; then compound 1; then compound 2.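

In this assay, this position responds to a small change as well as a large one: a group of 3 heavy atoms in place of a group of 4 gives a number 14.5 percentage points lower from compound 1 to compound 3 (beyond the scatter), and in place of a group of 7 it gives a number 38.6 percentage points lower from compound 2 to compound 3 (beyond the scatter). Across these three compounds, inhibition rises with the size of the group, and none goes against that order. No measurement shown explains this trend. From the compounds shown here alone, whether a longer chain would raise inhibition further remains open. So does whether an amide, with oxygen in place of sulfur, would serve equally well.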